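Chlorophenyl replacing methyl on a triazole: moving the chlorine

This account rests on a few compounds, and the source may have more. Where it says the series, first, only, none or still open, it means among the compounds named here.

Compound 1 `CCCCCCOc1ccc(-n2cnnc2C)cc1`: 22.8 mg/kg
Compound 2 `CCCCCCOc1ccc(-n2cnnc2-c2ccc(Cl)cc2)cc1`: 19.7 mg/kg

In a functional assay on the whole organism (strain C57B/6) with Mus musculus as the target, in the maximal electroshock model (a higher number here means that more compound is needed for the effect, a lower number that less compound is needed), compound 1 gives 22.8 mg/kg. For the measured compounds named here, the only comparison available is a 1.2-fold lower number from compound 1 to compound 2 (0.06 log units; within the scatter), so compound 1 and compound 2 cannot be told apart on these numbers. Compound 3 `CCCCCCOc1ccc(-n2cnnc2-c2ccccc2Cl)cc1` differs from compound 1 by 2-chlorophenyl in place of methyl on an aromatic carbon. Going by the values given here, the one measured step that bears on it, a 1.2-fold lower number from compound 1 to compound 2 (0.06 log units; within the scatter), placed a chlorophenyl on the same carbon and left the number essentially unchanged. A similar outcome is therefore expected here, with no step beyond the scatter: for compound 3 the estimate in this assay is 21 mg/kg, between 10 mg/kg and 45 mg/kg, corresponding to a 1.1-fold lower number from compound 1 to compound 3 (0.04 log units; within the scatter).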

Compound 3, dose for half-maximal effect: 13.2 mg/kg
Estimate against measurement, compound 3: 1.6-fold (0.20 log units) above, and the stated range covers the measured number.
By their numbers in this assay, from the lowest: compounds 3, 2 and 1 (each within the scatter of the next).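

In this assay, 2-chlorophenyl on this carbon, between two ring nitrogen atoms, still gives only steps within the scatter, with a 1.7-fold lower number from compound 1 to compound 3 (0.24 log units; within the scatter) and a 1.5-fold lower number from compound 2 to compound 3 (0.17 log units; within the scatter). On these numbers, neither the exchange of methyl for 2-chlorophenyl nor the shift of the chlorine from the 4-chlorophenyl arrangement separates the compounds at this position. No available evidence accounts for these numbers. As far as these compounds go, whether an amine or a carboxylic acid in place of the chlorine would give a step beyond the scatter remains open.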